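Methoxy to hydroxy on the shared core of compound 3

A few compounds are considered here, and "the series" means these few. Any claim that something is new, unique, unknown or untested is made for them only; others in the source may bear on it.

Of the compounds shown here, three sharing one core have been tested in a functional assay on Hs-578T cells (Homo sapiens) for cytotoxicity, read by sulforhodamine B assay, with a stated time of 48 h, tested at 100 nM; a higher number here means a weaker effect of the compound at the concentration tested, a lower number a stronger effect. Compound 1 `COc1cc(C)cc(-c2nn(CC#N)cc2-c2ccc(-c3cccc(C(C)=O)c3)nc2)c1` gives 61%, and compound 2 `Cc1cc(O)cc(-c2nn(CC#N)cc2-c2ccnc(-c3ccc(Oc4ccccc4)cc3)c2)c1` gives 82%. Compound 3 `COc1cc(C)cc(-c2nn(CC#N)cc2-c2ccnc(-c3ccc(N(C)C)cc3)c2)c1` gives -19%, the lowest of the three numbers and therefore the strongest effect; its step to compound 1 and its step to compound 2 both lie beyond the scatter.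

Compound 4 `Cc1cc(O)cc(-c2nn(CC#N)cc2-c2ccnc(-c3ccc(N(C)C)cc3)c2)c1` has not yet been measured. It differs from compound 3 in one place: hydrogen in place of methyl on an oxygen on an aromatic ring. Among the measured compounds shown here, no pair of measured compounds shows this change, so its effect is unknown here. The expectation is a modest step in this assay from compound 3 to compound 4, a number 29 percentage points higher from compound 3 to compound 4 (beyond the scatter), towards a weaker effect. Compound 4 is estimated at 10%, within a range from -30% to 60%.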

Compound 4, a percentage reported as activity, at one concentration (the size of the read-out at that concentration, not a potency): 82%
Beside the measured number, compound 4's estimate is 72 percentage points below it, and the stated range ends below it.
By their numbers in this assay, from the lowest: compound 3; then compound 1; then compounds 2 and 4 (each within the scatter of the next).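

In this assay, hydrogen in place of methyl on the oxygen, that is methoxy to hydroxy, is a large change, a number 101 percentage points higher from compound 3 to compound 4 (beyond the scatter), so among these compounds this small edit separates a strong effect from a weak one. With hydroxy in place, dimethylamino in place of phenoxy gives no change at the digits printed from compound 2 to compound 4 (within the scatter), so that group alone does not preserve the effect of compound 3. Nothing available here explains this result. From the compounds shown here alone, whether a longer chain such as ethyl on that oxygen preserves the effect remains open. So does how phenoxy would behave alongside methoxy.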